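Methoxy on the pendant phenyl of a quinoline carboxamide

A few compounds are considered here, and "the series" means these few. Any claim that something is new, unique, unknown or untested is made for them only; others in the source may bear on it.

Compound 1 `COc1cc2c(Oc3ccc(NC(=O)c4cc(-c5ccccc5)nc5ccccc45)cc3F)ccnc2cc1OCCCN1CCC(C)CC1` gives 120 nM in a functional assay on HT-29 cells (Homo sapiens) for cytotoxicity, read by MTT assay, with a stated time of 72 h; a lower number here means a stronger inhibitor, a higher number a weaker inhibitor. Compound 2 `COc1ccc(-c2cc(C(=O)Nc3ccc(Oc4ccnc5cc(OCCCN6CCC(C)CC6)c(OC)cc45)c(F)c3)c3ccccc3n2)cc1` gives 1110 nM. Compound 3 `COc1cc2c(Oc3ccc(NC(=O)c4cc(-c5ccccc5)nc5ccc(F)cc45)cc3F)ccnc2cc1OCCCN1CCCCC1` gives 120 nM.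

Compound 2 differs from compound 1 only by methoxy in place of hydrogen on an aromatic carbon, and that change gave a 9.3-fold higher number from compound 1 to compound 2 (0.97 log units; beyond the scatter). Compound 4 `COc1cccc(-c2cc(C(=O)Nc3ccc(Oc4ccnc5cc(OCCCN6CCCCC6)c(OC)cc45)c(F)c3)c3cc(F)ccc3n2)c1` is not yet measured; it differs from compound 3 by methoxy in place of hydrogen on an aromatic carbon, the same kind of change, though the entering group here sits meta to a large group rather than para to it. The difference between the core of compound 3 and the core of compound 1 is not broken down here; their values agree within the scatter.

For compound 4 the step of a 4.2-fold higher number from compound 3 to compound 4 (0.62 log units; beyond the scatter) is expected, resting on a 9.3-fold higher number from compound 1 to compound 2 (0.97 log units; beyond the scatter) but discounted for the shifted place. Compound 4 is therefore estimated at 500 nM, between 150 nM and 1600 nM.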

Compound 4, half-maximal inhibitory concentration: 2500 nM
For compound 4 the middle estimate is 5.0-fold (0.70 log units) below the measured one, outside the stated range (above it).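

Methoxy in place of hydrogen again gave a higher number on the core of compound 3, with a 21-fold higher number from compound 3 to compound 4 (1.32 log units; beyond the scatter), so in this assay the change went the same way on both cores shown. The two steps do not differ in size beyond the scatter: the same change on two cores in this assay, a 9.3-fold higher number (0.97 log units; beyond the scatter) from compound 1 to compound 2 and a 21-fold higher number (1.32 log units; beyond the scatter) from compound 3 to compound 4, 2.3-fold (0.35 log units) apart, within the scatter of two such steps. Within the data shown here, this rests on only two pairs, and the methoxy sits meta to a large group in compound 4 but elsewhere in compound 2, so these pairs do not separate the effect of place from that of core.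

The compounds shown leave open whether an ethoxy, a hydroxyl or an amine in place of the methoxy would give a similar step. They also leave open whether the step would hold on other cell lines.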